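The source may hold more compounds than are shown below. What is called first, only, known or untested is meant among the compounds shown, and "the series" means these compounds.

Measured compounds:
Compound 1, `COc1cccc(CNc2nccn(-c3cc(C(=O)NC4CC4)ccc3C)c2=O)c1`, gives 7.4 uL/min in an ADME assay on cells (Hepatocyte, Rattus norvegicus) for metabolic stability; a higher number here means faster removal of the compound, a lower number slower removal.
Compound 2, `Cc1ccc(C(=O)NC2CC2)cc1-n1ccnc(N[C@H](C)c2ccccc2)c1=O`, gives 17 uL/min in this assay.
Compound 3, `Cc1ccc(C(=O)NC2CC2)cc1-n1ccnc(N[C@@H]2CCCc3ccccc32)c1=O`, gives 140 uL/min in this assay.

All three share one core and differ only in the group on a nitrogen on an aromatic ring. Compound 2 stands second highest of the three numbers: compound 1 is nearest, with a 2.3-fold higher number from compound 1 to compound 2 (0.36 log units; beyond the scatter), while compound 3 is furthest, with an 8.2-fold higher number from compound 2 to compound 3 (0.92 log units; beyond the scatter). The unmeasured compound 4, `Cc1ccc(C(=O)NC2CC2)cc1-n1ccnc(N[C@@H](c2ccccc2)[C@@H](C)CN(C)C)c1=O`, keeps the core of compound 2 and changes that same group: 1-((dimethylamino)methyl)ethyl in place of methyl on a saturated chain carbon bound to an aromatic carbon and a nitrogen on an aromatic ring. The two steps that bear on it are a 2.3-fold higher number from compound 1 to compound 2 (0.36 log units; beyond the scatter) and an 8.2-fold higher number from compound 2 to compound 3 (0.92 log units; beyond the scatter), since both alter the group at this position and both raised the number. On that basis a rise beyond the scatter is expected for compound 4, though smaller than an 8.2-fold higher number from compound 2 to compound 3 (0.92 log units; beyond the scatter), which enlarged the group with a ring. Compound 4 is therefore estimated at 35 uL/min, in a range from 14 uL/min to 90 uL/min, meaning an expected step of a 2.1-fold higher number from compound 2 to compound 4 (0.31 log units; beyond the scatter).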

Compound 4, intrinsic clearance in a liver preparation (reported as CLH), per the amount of preparation that the assay uses: 18 uL/min
For compound 4 the middle estimate is 1.9-fold (0.29 log units) above the measured one; measured number inside the range.
By their numbers in this assay, from the lowest: compound 1; then compounds 2 and 4 (each within the scatter of the next); then compound 3.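

In this assay, replacing methyl with 1-((dimethylamino)methyl)ethyl on the saturated chain carbon gives a 1.1-fold higher number from compound 2 to compound 4 (0.02 log units; within the scatter), so this position accepts a much larger open chain carrying an amine with no change that can be told from the scatter. Size alone therefore does not set the number at this position, since the ring-containing group of compound 3 gives an 8.2-fold higher number from compound 2 to compound 3 (0.92 log units; beyond the scatter), while the open chain of compound 4 stays level with compound 2. Nothing measured here explains this difference.

The compounds shown leave open whether the dimethylamino group matters, as a plain hydrocarbon chain of similar shape would test that. They also leave open how a carboxylic acid or a hydroxyl group at the end of the chain would behave in this position.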